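The source may report more compounds than this note shows. Statements on the series, on what has been measured and on what is new or still open speak of the compounds shown alone.

In an assay on HEK293 cells for displacement of a labelled ligand from NPC1-like intracellular cholesterol transporter 1 (Homo sapiens) (on this read-out lower numbers stand for stronger inhibition and higher numbers for weaker inhibition), compound 2 `CC1CCCN(C(=O)CN2CN(c3ccccc3)C3(CCN(C(=O)c4ccc(C(C)(C)C)cc4)CC3)C2=O)C1` gives 12000 nM. Compound 1 `CC(C)(C)OC(=O)NCCCCCNC(=O)CN1CN(c2ccccc2)C2(CCN(C(=O)c3ccc(C(C)(C)C)cc3)CC2)C1=O` gives 13700 nM in this assay, and the two numbers lie within the usual scatter of each other, so neither can be called the stronger one. Compound 2 simply holds the lower of the two numbers shown, by a margin that means nothing. Compound 3 `CC(C)(C)c1ccc(C(=O)N2CCC3(CC2)C(=O)N(CC(=O)NCCCCNS(C)(=O)=O)CN3c2ccccc2)cc1` differs from compound 2 in one place: (4-(methanesulfonamido)butyl)amino in place of 3-methylpiperidin-1-yl on a carbonyl carbon. Within the data shown here, no measured pair here shares this change, so nothing shows directly how this assay answers it. What the data do offer is that compound 1, which carries an open chain in the same position rather than a ring, sits at 13700 nM, no different from compound 2 within the scatter. On that slim footing the estimated step of a 1.1-fold higher number from compound 2 to compound 3 (0.03 log units; within the scatter) is expected to stay within the scatter, with no clear direction. Compound 3 is therefore expected to give about 13000 nM in this assay, with a likely range from 5000 nM to 35000 nM.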

Compound 3, half-maximal inhibitory concentration: 4500 nM
The estimate for compound 3 lay 2.9-fold (0.46 log units) above the measured number; the whole stated range lies above it.
By their numbers in this assay, from the lowest: compound 3; then compounds 2 and 1 (each within the scatter of the next).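

In this assay, compound 1 and compound 2 could not be told apart, but this position on a carbonyl carbon does respond to what it carries: (4-(methanesulfonamido)butyl)amino in place of 3-methylpiperidin-1-yl gives a 2.7-fold lower number from compound 2 to compound 3 (0.43 log units; beyond the scatter), a modest step beyond the scatter. Losing the ring is not enough to explain this, since compound 1 also carries an open chain, and methanesulfonamido in place of ((tert-butoxycarbonyl)amino)methyl gives a 3.0-fold lower number from compound 1 to compound 3 (0.48 log units; beyond the scatter), so what sits along the chain matters as well, although this one change replaces the end group and shortens the chain together. No measurement here bears on why the number falls.

Still open, as far as these compounds go, is whether the methanesulfonamido group itself is needed, or whether an amine, a carboxylic acid or an acetamide on the same butyl chain would serve equally well. Also open, from the compounds shown here alone, is how the number would move with a longer or a shorter chain ending in the same methanesulfonamido group.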